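The source may report more compounds than this note shows. Statements on the series, on what has been measured and on what is new or still open speak of the compounds shown alone.

The three compounds measured so far, all in an ADME assay on microsomes from liver (Canis lupus familiaris) for metabolic stability, with a stated time of 10 min, tested at 1 uM; on this read-out higher numbers stand for a more stable compound and lower numbers for a less stable compound:

Compound 1, `Cc1cc(C(F)(F)F)ccc1-c1cc2cnn([C@@H](CC(C)C)c3ccc(C(=O)NCCC(=O)O)cc3)c2cc1C`, gives 80%.
Compound 2, `Cc1cc(C(F)(F)F)ccc1-c1ccc2nn([C@@H](CC(C)C)c3ccc(C(=O)NCCC(=O)O)cc3)cc2c1C`, gives 64%.
Compound 3, `Cc1cc2c(cnn2[C@@H](CC(C)C)c2ccc(C(=O)NCCC(=O)O)cc2)cc1-c1ccc(C(F)(F)F)cc1Cl`, gives 65%.

Compound 1 and compound 3 share a core and differ in one place: chloro in place of methyl on an aromatic carbon. That change brought a number 15 percentage points lower from compound 1 to compound 3 (beyond the scatter).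

Compound 2 carries the same atoms as compound 1, joined differently; how the two cores differ is not broken down here. In this assay compound 2 and compound 3 lie within the scatter of each other, so no order can be read between them, while compound 1 stands beyond the scatter above compound 2.

Compound 4, `Cc1c(-c2ccc(C(F)(F)F)cc2Cl)ccc2nn([C@@H](CC(C)C)c3ccc(C(=O)NCCC(=O)O)cc3)cc12`, has not yet been measured. It relates to compound 2 as compound 3 relates to compound 1: chloro in place of methyl on an aromatic carbon. The surroundings of the change read the same in both pairs, so this is the same change made on the other core.

For the measured compounds named here, for compound 4 the step is expected to run in the same direction and at about the same size, a number 15 percentage points lower from compound 2 to compound 4 (beyond the scatter), resting on the single earlier instance, which gave a number 15 percentage points lower from compound 1 to compound 3 (beyond the scatter); with only one precedent, the range is kept wide. Compound 4 is therefore estimated at 49%, between 35% and 62%.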

Compound 4, percent of the compound remaining: 75%
Compound 4: middle estimate off by 26 percentage points, on the low side, outside the stated range (above it).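

In this assay, chloro in place of methyl on the 2-methyl-4-(trifluoromethyl)phenyl group gave a number 11 percentage points higher from compound 2 to compound 4 (beyond the scatter), so on this core the change ran the opposite way from the earlier step, and the two results differ by more than repeat measurements would explain: the same change on two cores in this assay, a number 15 percentage points lower (beyond the scatter) from compound 1 to compound 3 and a number 11 percentage points higher (beyond the scatter) from compound 2 to compound 4, 26 percentage points apart, beyond the scatter of two such steps

This shows that, in this series, the result of this change on one core cannot simply be carried over to the other, since the same swap of one group for another lowered the number in one pair and raised it in the other. For the compounds shown here, it does not show why the two cores part ways, and with only one pair on each core, neither direction can be called typical of its core or of the change in general.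

The compounds shown leave open how other groups on the same aromatic carbon would behave on the two cores, such as a fluoro group or a nitrile, and whether they too would split in direction. They also leave open whether the split would persist if the carboxylic acid chain shared by all four compounds were replaced by a different chain, such as one ending in an amine.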